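A few compounds are considered here, and "the series" means these few. Any claim that something is new, unique, unknown or untested is made for them only; others in the source may bear on it.

Working notes on the series. Compound 1 `COc1cc(C(=O)Nc2nn[nH]n2)nc(-c2ccccc2)c1` in a functional assay on the whole organism for inhibition, with Rattus norvegicus as the target, at a dose of 10 mg/kg by the oral route (on this read-out lower numbers stand for a weaker effect and higher numbers for a stronger effect at the one dose given), gives 100%. Compound 2 `COc1cc(C(=O)Nc2nn[nH]n2)nc(-c2ccc(NC(C)=O)cc2)c1`, which carries acetamido in place of hydrogen on an aromatic carbon, gives in this assay a value of 100%, so that the step of no change at the digits printed from compound 1 to compound 2 (within the scatter) stays within the scatter. Within the data shown here, compound 1 therefore stands level with compound 2 on the numbers available, and no measured compound in the set lies apart from it.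

Compound 3 `Cc1cc(C(=O)Nc2nn[nH]n2)nc(-c2ccccc2)c1` is the next unmeasured member. It differs from compound 1 in one place: methyl in place of methoxy on an aromatic carbon. Among the measured compounds shown here, the one measured step concerns a different position and a different group, so it bears on this change only in a general way; it showed no movement in this assay. Nothing in the set points to a step beyond the scatter, and the expectation for compound 3 is a read-out of 95%, within a range from 80% to 100%. This estimate means a step of a number 5 percentage points lower from compound 1 to compound 3 (within the scatter) that is expected to stay within the scatter.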

Compound 3, a percentage reported as inhibition, in the whole organism at one dose (the size of the read-out at that dose, not a potency): 88%
Compound 3: middle estimate off by 7 percentage points, on the high side; measured number inside the range.
By their numbers in this assay, from the lowest: compound 3; then compounds 1 and 2 (each within the scatter of the next).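

Unlike the acetamido step, where no change at the digits printed from compound 1 to compound 2 (within the scatter), the change at the position opposite the ring nitrogen moves the read-out: in this assay, a number 12 percentage points lower from compound 1 to compound 3 (beyond the scatter). This position is therefore not indifferent to its group at this dose, although the step is modest and rests on a single pair, with methoxy leaving and methyl entering, one heavy atom and one hydrogen-bond acceptor fewer. Nothing available gives a reason for this step.

From the compounds shown here alone, it remains open whether an ethoxy group, a hydroxyl group or an amine at this position would stay level with methoxy or fall to the level of methyl. Also open, going by these compounds, is whether acetamido on the phenyl group would still leave the read-out unmoved with methyl in place of methoxy.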